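Pyridinyl Substitution on the Fused Ring of the Series

This account rests on a few compounds, and the source may have more. Where it says the series, first, only, none or still open, it means among the compounds named here.

Measured so far:
compound 1 `C[C@H](Oc1ccc(S(C)(=O)=O)cc1C(=O)N1Cc2ccccc2C1)C(F)(F)F`: 2540 nM
compound 2 `Cc1cccc2c1CN(C(=O)c1cc(S(C)(=O)=O)ccc1O[C@@H](C)C(F)(F)F)C2`: 3360 nM

Compound 1 holds the lowest of the two numbers in an assay on CHO cells for inhibition of sodium- and chloride-dependent glycine transporter 1 (Homo sapiens), read by scintillation counting (a lower number here means that less compound is needed, a higher number that more compound is needed for the effect), with compound 2 nearest; the step of a 1.3-fold higher number from compound 1 to compound 2 (0.12 log units; within the scatter) is within the scatter, so the two compounds cannot be ordered on these data.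

Compound 3 `C[C@H](Oc1ccc(S(C)(=O)=O)cc1C(=O)N1Cc2ccc(-c3ccncc3)cc2C1)C(F)(F)F` is not yet measured. Its difference from compound 1 is pyridin-4-yl in place of hydrogen on an aromatic carbon.

For the measured compounds named here, only one measured step bears on this change, and only loosely: a 1.3-fold higher number from compound 1 to compound 2 (0.12 log units; within the scatter), also a replacement of hydrogen on an aromatic carbon of the fused ring system, but by a methyl and at a different place. It gave no step beyond the scatter. Going by the values given here, no measured pair covers a larger group entering at the position used in compound 3, nor a ring bearing a hydrogen-bond acceptor, so the direction of any shift is not known from the series.

On this basis compound 3 is expected to remain close to compound 1, with the estimated step of a 1.0-fold lower number from compound 1 to compound 3 (0.01 log units; within the scatter). Compound 3 is estimated at 2500 nM in this assay, in a range from 700 nM to 9000 nM, the width reflecting the lack of a matching measured change.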

Compound 3, half-maximal effective concentration: 17 nM
Estimate against measurement, compound 3: 150-fold (2.17 log units) above; measured number outside the range, below it.
By their numbers in this assay, from the lowest: compound 3; then compounds 1 and 2 (each within the scatter of the next).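

In this assay, pyridin-4-yl in place of hydrogen on an aromatic carbon, meta to a fused ring and para to a fused ring, gives a 150-fold lower number from compound 1 to compound 3 (2.17 log units; beyond the scatter) and marks this carbon as one where a substituent can move the number by a large margin. For the compounds shown here, the only earlier change on the fused ring system, methyl at a different place, gave a 1.3-fold higher number from compound 1 to compound 2 (0.12 log units; within the scatter) and showed no such sensitivity; those two steps differ in both group and place, so they do not tell which of the two accounts for the contrast. No measurement at hand bears on the reason for the size of the new step.

Open, going by these compounds, is whether the whole ring or its nitrogen carries the effect, which phenyl or pyridin-3-yl on the same carbon would separate, and whether a small group such as chlorine or methyl on that carbon, or an amine such as morpholine, would move the number at all. Also open, on these data alone, is whether the step holds with the other parts of the core of compound 1 changed, for example with a different group in place of the methylsulfonyl.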